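From Trifluoromethyl to Nitro on Compound 2

The source may report more compounds than this note shows. Statements on the series, on what has been measured and on what is new or still open speak of the compounds shown alone.

Compound 1 (`CC1=C(/C=C/C(=O)/C=C/c2cccc(C(F)(F)F)c2)C(C)(C)CCC1`), 7700 nM
Compound 2 (`CC1=C(/C=C/C(=O)/C=C/c2cccc(C(F)(F)F)c2)C(C)(C)CCC1O`), 3500 nM

Both values come from a functional assay on PC-3 cells (Homo sapiens) for cytotoxicity, read by MTT assay, with a stated time of 72 h (on this read-out lower numbers stand for stronger inhibition and higher numbers for weaker inhibition), and compound 2 holds the lower number of the two. Among the compounds with values here, the only measured step is a 2.2-fold lower number from compound 1 to compound 2 (0.34 log units; beyond the scatter) and is a modest one, with hydroxy in place of hydrogen on a saturated ring carbon. Compound 3 (`CC1=C(/C=C/C(=O)/C=C/c2cccc([N+](=O)[O-])c2)C(C)(C)CCC1O`) keeps that hydroxy and differs from compound 2 by nitro in place of trifluoromethyl on an aromatic carbon with nitro in place of trifluoromethyl on an aromatic carbon. Since a 2.2-fold lower number from compound 1 to compound 2 (0.34 log units; beyond the scatter) sits on a saturated ring carbon and not on the aromatic carbon, it offers no guide to size or direction here, and no step beyond the scatter is expected in this assay for this change. The expected step is a 1.1-fold lower number from compound 2 to compound 3 (0.04 log units; within the scatter) as an estimate only. For compound 3 the estimated value is 3200 nM with an expected range from 1100 nM to 9000 nM.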

Compound 3, half-maximal inhibitory concentration: 5800 nM
For compound 3 the middle estimate is 1.8-fold (0.26 log units) below the measured one; low and high end bracket the measured number.
By their numbers in this assay, from the lowest: compounds 2, 3 and 1 (each within the scatter of the next, the first and the last beyond it).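

In this assay, within the data shown here, a 1.7-fold higher number from compound 2 to compound 3 (0.22 log units; within the scatter) is the first measured change at the aromatic carbon, and it shows that nitro can stand in place of trifluoromethyl there, meta to a large group, without a step beyond the scatter. The earlier pair changed only a saturated ring carbon and said nothing about this position, where the two groups, despite their different heavy atoms and hydrogen-bond acceptors, cannot be told apart on this read-out. Nothing at hand accounts for this result.

From the compounds shown here alone, it remains open whether an amine or a carboxylic acid on the same aromatic carbon would also stay within the scatter of compound 2. The compounds shown also leave open whether nitro in place of trifluoromethyl would give a similar result on the core of compound 1, which lacks the hydroxy.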